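This account rests on a few compounds, and the source may have more. Where it says the series, first, only, none or still open, it means among the compounds named here.

Measured compounds:

Compound 1, `CNCc1cc(-c2cccnc2F)n(S(=O)(=O)c2cccs2)c1`, in a functional assay on the whole organism (strain Jcl:Sprague-Dawley) for inhibition, with Rattus norvegicus as the target, with stated times of 3 min and 3 h, at a dose of 1 mg/kg by the intravenous route (on this read-out lower numbers stand for less inhibition and higher numbers for more inhibition at the one dose given (going by the name of the read-out)), gives 96%.
Compound 2, `CNCc1cn(S(=O)(=O)c2cccs2)c(-c2cccnc2F)c1F`, in this assay gives 98%.
Compound 3, `CNCc1cn(S(=O)(=O)c2ccco2)c(-c2cccnc2F)c1F`, in this assay gives 75%.

Compound 3 stands lowest of the three in this assay; its nearest neighbour is compound 1 and its furthest is compound 2, and both gaps lie beyond the scatter. Compound 4, `CNCc1cn(S(=O)(=O)c2ccccn2)c(-c2cccnc2F)c1F`, has not been measured in this assay. It differs from compound 3 in one place: pyridin-2-yl in place of furan-2-yl on a sulfonyl sulfur.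

Of the two measured steps, only one touches the same place. That step, a number 23 percentage points lower from compound 2 to compound 3 (beyond the scatter), shows that swapping the group on the sulfonyl sulfur can move the read-out in this assay by a modest amount. The other step, a number 2 percentage points higher from compound 1 to compound 2 (within the scatter), sits elsewhere and does not bear on this change. Nothing measured shows what pyridin-2-yl does on the sulfonyl sulfur, so the direction is open; a modest step either way, or none beyond the scatter, is plausible. The estimate for compound 4 in this assay is 80%, with a range from 55% to 97%, which means an expected step of a number 5 percentage points higher from compound 3 to compound 4 (within the scatter).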

Compound 4, a percentage reported as inhibition, in the whole organism at one dose (the size of the read-out at that dose, not a potency): 95%
The estimate for compound 4 lay 15 percentage points below the measured number, within the range that was stated.
By their numbers in this assay, from the lowest: compound 3; then compounds 4, 1 and 2 (each within the scatter of the next).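

The earlier compounds shown here showed only that furan-2-yl on the sulfonyl sulfur read lower than thiophen-2-yl, whereas pyridin-2-yl gives a number 20 percentage points higher from compound 3 to compound 4 (beyond the scatter) in this assay and so shows that an aromatic ring in this place can restore much of what furan-2-yl lost. Set against thiophen-2-yl, the same group gives a number 3 percentage points lower from compound 2 to compound 4 (within the scatter) and thus shows that a six-membered aromatic ring can stand in for the five-membered thiophen-2-yl here without a change beyond the scatter. No evidence is available on why furan-2-yl reads lower than the other two groups.

The compounds shown leave open how a phenyl or pyridin-3-yl group on the sulfonyl sulfur would read in this assay and whether a dimethylamino group could take the place of an aromatic ring there. They also leave open whether pyridin-2-yl would behave the same way on the core of compound 1, which lacks the fluoro group.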